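Methyl Added Twice: One Step Seen, One Still Unknown

The source may report more compounds than this note shows. Statements on the series, on what has been measured and on what is new or still open speak of the compounds shown alone.

Of the compounds shown here, three have been tested in a functional assay on J774 cells (Mus musculus) for cytotoxicity, read by resazurin assay (a lower number here means a stronger inhibitor, a higher number a weaker inhibitor), so far, and a fourth is still to be tested there. Compound 1 `OCCCCCC(O)c1ccc(-c2ccc(F)cc2)cc1` and compound 2 `Cc1cc(F)ccc1-c1ccc(C(O)CCCCCO)cc1` share one core; compound 3 `O=C(CCCCCO)c1ccc(-c2ccc(F)cc2F)cc1` and compound 4 `Cc1cc(-c2ccc(F)cc2F)ccc1C(=O)CCCCCO` share another. The difference between the two cores is not broken down here.

In this assay compound 1 gives 18000 nM. Compound 2 differs from compound 1 by methyl in place of hydrogen on an aromatic carbon, and in this assay compound 2 gives 20000 nM. That step, a 1.1-fold higher number from compound 1 to compound 2 (0.05 log units; within the scatter), is small enough to count as no change at all.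

In this assay compound 3 gives 6000 nM, the lowest of the three numbers, and its distance from compound 1 and from compound 2 lies beyond the scatter in both cases. Compound 4 differs from compound 3 by methyl in place of hydrogen on an aromatic carbon. Among the compounds with values here, this is the same kind of change as the one from compound 1 to compound 2, but the surroundings differ: in the first case the methyl sits ortho to a large group and meta to a fluoro group, in the second ortho to a group of 8 heavy atoms and meta to another group of 8 heavy atoms.

Within the data shown here, on the one earlier step, the change is expected to be a 1.1-fold higher number from compound 3 to compound 4 (0.04 log units; within the scatter), because a 1.1-fold higher number from compound 1 to compound 2 (0.05 log units; within the scatter) stayed within the scatter. Among the measured compounds shown here, compound 4 is therefore expected to give about 6600 nM in this assay, with a range of 3000 nM to 14000 nM that is wide, since only one step backs the expectation.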

Compound 4, half-maximal inhibitory concentration: 4000 nM
For compound 4 the middle estimate is 1.7-fold (0.22 log units) above the measured one; measured number inside the range.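

In this assay the new step is a 1.5-fold lower number from compound 3 to compound 4 (0.18 log units; within the scatter), so adding the methyl to this second core counts as no real change, just as it did on the first. Set side by side, the two steps agree, and on these two cores the change carries over without a visible difference: the same change on two cores in this assay, a 1.1-fold higher number (0.05 log units; within the scatter) from compound 1 to compound 2 and a 1.5-fold lower number (0.18 log units; within the scatter) from compound 3 to compound 4, 1.7-fold (0.22 log units) apart, within the scatter of two such steps. This shows only that the methyl made no change beyond the scatter in these two pairs; it does not show that the same would hold on a further core, and steps this small cannot settle whether the methyl has a slight real effect that the scatter hides.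

The compounds shown leave open whether a different group on that aromatic carbon, such as an amine, a carboxylic acid or a longer chain, would also leave the number in this assay unchanged. They also leave open which part of the difference between the two cores goes with the gap between compound 1 and compound 3, as those two differ in more than one place.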